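Double-bond geometry in the acetate series: compound 2 to compound 4

The compounds below may be only part of what the source reports. "The series", "measured", "known", "first", "only" and "open" are said of these compounds alone.

In a functional assay on A549 cells (Homo sapiens) for inhibition, read by XTT assay, with a stated time of 48 h (a lower number here means a stronger inhibitor, a higher number a weaker inhibitor), compound 1 `CC(=O)OC/C(=C\c1ccccc1F)C(=O)c1ccccc1` gives 68700 nM and compound 2 `CC(=O)OC/C(=C\c1ccc(Cl)cc1Cl)C(=O)c1ccccc1` gives 97000 nM, and these two values lie within the scatter of each other. Compound 3 `C/C=C(\COC(=O)c1ccccc1)C(=O)c1ccc(OC)cc1` gives > 100000 nM, which is a limit of the assay and not a number. Compound 2 therefore stands among the two measured numbers in this small set, with no separation from compound 1 and with the reported range close to its end.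

The next compound is compound 4 `CC(=O)OC/C(=C/c1ccc(Cl)cc1Cl)C(=O)c1ccccc1`, and its relation to compound 2 is simple: the two compounds have the same atoms and bonds and differ only in configuration as drawn: 1 of 1 stereo elements differ; a double bond is drawn E in compound 2 and Z in compound 4. Among the compounds with values here, no measured pair isolates a change of this kind, so the size of the step cannot be read from the data. The expectation in this assay is therefore no step beyond the scatter, with a slight allowance for a lower number. The starting point is compound 2 at 97000 nM. A result reported only as a limit remains possible for compound 4. The expected change is a 1.4-fold lower number from compound 2 to compound 4 (0.14 log units; within the scatter). For compound 4 the estimated value is 70000 nM, with an expected range of 30000 nM to 100000 nM.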

Compound 4, half-maximal inhibitory concentration: 74500 nM
Compound 4: middle estimate off by 1.1-fold (0.03 log units), on the low side; the range from low to high includes it.
By their numbers in this assay, from the lowest: compounds 1, 4 and 2 (each within the scatter of the next). At a limit, above all of these: compound 3.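

Working notes: in this assay, this pair is the first in the series to isolate double-bond geometry, and it gives a 1.3-fold lower number from compound 2 to compound 4 (0.11 log units; within the scatter). Swapping the double bond from E as drawn in compound 2 to Z as drawn in compound 4 therefore leaves the read-out within the scatter, a result that compounds 1 and 3 could not give, since neither forms a geometry pair with another compound shown. The comparison is a clean one, as nothing else changes between the two structures: the fact that compounds 2 and 4 differ only in the configuration as drawn

Still open, on these data alone, is whether this insensitivity to geometry holds only for the aryl substitution of compound 2 or also elsewhere on the shared core, for instance with an amine or a carboxylic acid in place of the acetate. Compound 3, with its benzoate ester, stays at a limit of the assay, > 100000 nM, which is not a number and so offers no geometry comparison of its own.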